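Aryl amide swaps on the shared core, toward a methylpyridinyl amide

The source may hold more compounds than are shown below. What is called first, only, known or untested is meant among the compounds shown, and "the series" means these compounds.

Compound 2 `O=C(COc1ccc2cc(/C=C3/SC(=O)NC3=O)ccc2c1)Nc1cccc(C(F)(F)F)c1` stands at a limit of an assay on isolated protein for inhibition of histone deacetylase 8 (Homo sapiens), with a stated time of 1 h; on this read-out lower numbers stand for stronger inhibition and higher numbers for weaker inhibition: its reported value of > 50000 nM is a limit, not a number. Compound 1 `Cc1cc(Br)ccc1NC(=O)COc1ccc2cc(/C=C3/SC(=O)NC3=O)ccc2c1` gives 7400 nM in this assay. Compound 3 `Cc1ccc(NC(=O)COc2ccc3cc(/C=C4/SC(=O)NC4=O)ccc3c2)cc1Cl` is likewise reported only as a limit, > 50000 nM. The step to compound 4 `Cc1cccc(NC(=O)COc2ccc3cc(/C=C4/SC(=O)NC4=O)ccc3c2)n1` changes the aryl group on the amide nitrogen: 6-methylpyridin-2-yl in place of 3-(trifluoromethyl)phenyl on an amide-type nitrogen. For the measured compounds named here, two measured steps touch this position, an at least 6.7-fold higher number from compound 1 to compound 2 (0.82 log units; beyond the scatter) and an at least 6.7-fold higher number from compound 1 to compound 3 (0.82 log units; beyond the scatter), both ending at the limit, while the step that the two limits leave unreadable from compound 2 to compound 3 cannot be read because of the limit of > 50000 nM in this assay, at which 2 of the 3 values shown sit. Going by the values given here, no measured pair places a ring nitrogen in this aryl group, so the direction of the change is open; a step of about an at least 1.2-fold lower number from compound 2 to compound 4 (0.09 log units; that floor lies within the scatter) is expected. Compound 4 is estimated at 40000 nM, within 8000 nM to 150000 nM, with a fair chance of another limit.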

Compound 4, half-maximal inhibitory concentration: 7500 nM
Compound 4: the middle estimate sits 5.3-fold (0.73 log units) above what was measured; the whole stated range lies above it.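

In this assay, as far as these compounds go, 6-methylpyridin-2-yl on the amide nitrogen gives an at least 6.6-fold lower number from compound 2 to compound 4 (0.82 log units; beyond the scatter) and an at least 6.6-fold lower number from compound 3 to compound 4 (0.82 log units; beyond the scatter); both steps start from a limit, so their true size stays open. Until now only compound 1 had given a number at this position, and with a 1.0-fold higher number from compound 1 to compound 4 (0.01 log units; within the scatter) the two stand level, so a readable value is not tied to the 4-bromo-2-methylphenyl group.

The compounds shown do not separate the share of the ring nitrogen from that of the methyl group. A plain pyridin-2-yl amide, or a pyridinyl amide carrying an amine in place of the methyl, would bear on this.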